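The compounds below may be only part of what the source reports. "The series", "measured", "known", "first", "only" and "open" are said of these compounds alone.

Measured so far in an in vitro functional assay on CHO/Galpha16 cells for antagonist activity at C-C chemokine receptor type 8 (Homo sapiens), read by FLIPR; a lower number here means a stronger inhibitor, a higher number a weaker inhibitor:
compound 1 `CCCC(=O)N1CCC(NS(=O)(=O)c2ccc(NC(=O)c3ccccc3)c3ccccc23)CC1` gives 12.5 nM;
compound 2 `CCCC(=O)N1CCC(NS(=O)(=O)c2ccc(NC(=O)c3cc(C)oc3C(F)(F)F)c3ccccc23)CC1` gives 46.9 nM.

Compound 1 stands with the lowest number of the two. For the measured compounds named here, the only measured step away from it, a 3.8-fold higher number from compound 1 to compound 2 (0.57 log units; beyond the scatter), weakened the inhibition.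

Compound 3 `CCCC(=O)N1CCC(NS(=O)(=O)c2ccc(NC(=O)c3nccn3C)c3ccccc23)CC1` has not yet been measured. It differs from compound 1 by 1-methyl-1H-imidazol-2-yl in place of phenyl on a carbonyl carbon. Going by the values given here, one measured step bears on this: there too the phenyl on the carbonyl carbon gave way to another ring, and the result was a 3.8-fold higher number from compound 1 to compound 2 (0.57 log units; beyond the scatter). Among the compounds with values here, on that single precedent a modest rise in the number, beyond the scatter, is the expectation here as well, though with one step as the only guide the size for the 1-methyl-1H-imidazol-2-yl group may well differ. For compound 3 the expected result is therefore 30 nM, with a range from 10 nM to 90 nM. That corresponds to an expected step of a 2.4-fold higher number from compound 1 to compound 3 (0.38 log units; beyond the scatter).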

Compound 3, half-maximal inhibitory concentration: 20.4 nM
Estimate against measurement, compound 3: 1.5-fold (0.17 log units) above; low and high end bracket the measured number.
By their numbers in this assay, from the lowest: compounds 1 and 3 (each within the scatter of the next); then compound 2.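

In this assay, the phenyl on the carbonyl carbon can give way to 1-methyl-1H-imidazol-2-yl with no change that stands clear of the scatter: a 1.6-fold higher number from compound 1 to compound 3 (0.21 log units; within the scatter). This position therefore accepts a five-membered aromatic ring with 2 hetero atoms and 2 hydrogen-bond acceptors, and the loss seen with 5-methyl-2-(trifluoromethyl)furan-3-yl does not follow every replacement of phenyl, as a 2.3-fold lower number from compound 2 to compound 3 (0.36 log units; beyond the scatter) shows. Nothing available gives a reason for either step.

Open, on these data alone, is how much of this result rests on the ring nitrogens and how much on the methyl group, a question that a pyridin-2-yl ring or a 1H-imidazol-2-yl group without the methyl would bear on. Also open, as far as these compounds go, is whether any group here can give a number clearly lower than that of compound 1, at 12.5 nM.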